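Chain lengthening on the shared core: cytotoxicity expectation

The source may report more compounds than this note shows. Statements on the series, on what has been measured and on what is new or still open speak of the compounds shown alone.

Values in a functional assay on HeLa cells (Homo sapiens) for cytotoxicity, read by MTT assay, with a stated time of 24 h; on this read-out higher numbers stand for weaker inhibition and lower numbers for stronger inhibition:
- compound 1 `CCCCCCCCCCn1cc(-c2nc3ccccc3cc2C)nn1`: 28.2 ug/mL
- compound 2 `CCCCCCCCCCn1cc(-c2nc3ccccc3cc2CCCC)nn1`: > 100 ug/mL
- compound 3 `Cc1cc2ccccc2nc1-c1cn(CCC(F)(F)C(F)(F)C(F)(F)C(F)(F)C(F)(F)C(F)(F)C(F)(F)C(F)(F)F)nn1`: > 100 ug/mL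

Compound 2 gives only a limit of this assay, not a number. Compound 3 likewise stands at a limit, not a number (the limit of > 100 ug/mL in this assay, at which 2 of the 3 values shown sit). Compound 4 `CCCCCc1cc2ccccc2nc1-c1cn(CCC(F)(F)C(F)(F)C(F)(F)C(F)(F)C(F)(F)C(F)(F)C(F)(F)C(F)(F)F)nn1` differs from compound 3 by butyl in place of hydrogen on a saturated chain carbon bound to an aromatic carbon. Among the measured compounds shown here, the only measured step of the same kind is an at least 3.5-fold higher number from compound 1 to compound 2 (0.54 log units; beyond the scatter), which ended at the limit. The step from compound 3 to compound 4 is therefore expected to leave the number at or beyond that limit, with no decrease foreseen. Compound 4 is estimated at 200 ug/mL in this assay, between 100 ug/mL and 500 ug/mL. The expected step is a step that the limit leaves unreadable from compound 3 to compound 4.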

Compound 4, half-maximal inhibitory concentration: > 100 ug/mL
Compound 4 ended at the assay's limit (the forecaster's own chance of this, stated with the estimate: 90%); the middle value does not contradict the limit.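

No step can be read from compound 3 to compound 4, as both values are limits, not numbers: the limit of > 100 ug/mL in this assay, at which 3 of the 4 values shown sit.

The compounds shown leave open whether butyl in place of hydrogen changes cytotoxicity on compound 3 at all.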